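Removing the chain methyl from the weakest stereoisomer

A few compounds are considered here, and "the series" means these few. Any claim that something is new, unique, unknown or untested is made for them only; others in the source may bear on it.

Three stereoisomers of one ester share a single assay here. In a functional assay (ileum) for antagonist activity, with Cavia porcellus as the target (a lower number here means a stronger inhibitor, a higher number a weaker inhibitor), compound 1 `CC1=C(C(=O)O[C@H](C)CO[N+](=O)[O-])[C@H](c2cccc3nonc23)C([N+](=O)[O-])=C(C)C1` gives 36500 nM, the highest of the three numbers. Compound 2 `CC1=C(C(=O)O[C@@H](C)CO[N+](=O)[O-])[C@@H](c2cccc3nonc23)C([N+](=O)[O-])=C(C)C1` gives 577 nM in this assay, and compound 3 `CC1=C(C(=O)O[C@H](C)CO[N+](=O)[O-])[C@@H](c2cccc3nonc23)C([N+](=O)[O-])=C(C)C1` gives 59.6 nM. The steps are a 63-fold lower number from compound 1 to compound 2 (1.80 log units; beyond the scatter), a 610-fold lower number from compound 1 to compound 3 (2.79 log units; beyond the scatter) and a 9.7-fold lower number from compound 2 to compound 3 (0.99 log units; beyond the scatter); each of these rests on (the fact that compounds 1 and 2 differ only in the configuration as drawn), the fact that compounds 1 and 3 differ only in the configuration as drawn and (the fact that compounds 2 and 3 differ only in the configuration as drawn), since the three compounds have the same atoms and bonds.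

Compound 4 `CC1=C(C(=O)OCCO[N+](=O)[O-])[C@H](c2cccc3nonc23)C([N+](=O)[O-])=C(C)C1` differs from compound 1 by hydrogen in place of methyl on a saturated chain carbon bound to an oxygen next to a carbonyl group and a saturated chain carbon, while keeping the ring configuration as drawn in compound 1. Going by the values given here, the only measured step touching that chain carbon is a 9.7-fold lower number from compound 2 to compound 3 (0.99 log units; beyond the scatter), a modest one, whereas the ring carbon carries the large steps. Compound 4 is therefore expected to stay near compound 1, with a step of a 2.4-fold lower number from compound 1 to compound 4 (0.39 log units; beyond the scatter) expected in this assay. The estimate for compound 4 is 15000 nM, expected between 4000 nM and 60000 nM.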

Compound 4, half-maximal inhibitory concentration: 22400 nM
Compound 4: the middle estimate sits 1.5-fold (0.17 log units) below what was measured; the measured number falls inside the stated range.
By their numbers in this assay, from the lowest: compound 3; then compound 2; then compounds 4 and 1 (each within the scatter of the next).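

In this assay the exchange of methyl for hydrogen on the saturated chain carbon gives a 1.6-fold lower number from compound 1 to compound 4 (0.21 log units; within the scatter) and so no readable shift while the ring configuration stays as drawn in compound 1. Until now this carbon had been varied only by inversion, under the other ring configuration, in a 9.7-fold lower number from compound 2 to compound 3 (0.99 log units; beyond the scatter) and that step could not say what the methyl itself contributes; with the ring as in compound 1, the number stays in the same high range without that group, with compound 4 at 22400 nM in this series. The data shown offer no explanation for this result.

Still open, as far as these compounds go, is whether hydrogen in place of methyl would be equally silent under the ring configuration of compounds 2 and 3, where the configuration of this carbon does register. Also open, from the compounds shown here alone, is how an ethyl group or a longer chain on this carbon would read.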